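Alkynyl uracils and a nucleoside analogue: cytotoxicity notes

The compounds below may be only part of what the source reports. "The series", "measured", "known", "first", "only" and "open" are said of these compounds alone.

The series is read in an ADME assay on A549 cells (Homo sapiens) for cytotoxicity, read by MTT assay; a lower number here means that less compound is tolerated, a higher number that more compound is tolerated. Compound 1 `O=c1[nH]cc(C#CC2CC2)c(=O)[nH]1` gives 251000 nM. Within the data shown here, compound 2 `O=c1[nH]cc(C#CC2CCCCC2)c(=O)[nH]1` gives 245000 nM, a number that lies within the scatter of the one for compound 1. Compound 3 `CCCCC#Cc1cn([C@@H]2O[C@H](CO)[C@@H](O)[C@H]2O)c(=O)[nH]c1=O` gives 83200 nM, the lowest of the three numbers seen so far; compound 2 sits nearest and compound 1 furthest from it, and both of those gaps lie beyond the scatter.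

Compound 4 `O=c1[nH]c(=O)n([C@@H]2O[C@H](CO)[C@@H](O)[C@H]2O)cc1C#CC1CCCCC1` has not yet been run in this assay. Against compound 3 it differs as follows:

cyclohexyl in place of butyl on a triple-bonded carbon

Among the measured compounds shown here, nothing measured so far connects two compounds by this exact change. The pair of compound 1 and compound 2 differs in the ring on the triple-bonded carbon and shows no gap beyond the scatter, which is the only hint available on how much the group at that position matters. On that basis the step is expected to be small and not beyond the scatter in this assay, in no settled direction, so that a 1.1-fold higher number from compound 3 to compound 4 (0.03 log units; within the scatter) is the estimate. For compound 4 the expected value is 90000 nM, with a range from 40000 nM to 200000 nM.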

Compound 4, half-maximal cytotoxic concentration: 127000 nM
For compound 4 the middle estimate is 1.4-fold (0.15 log units) below the measured one, and the stated range covers the measured number.
By their numbers in this assay, from the lowest: compounds 3, 4, 2 and 1 (each within the scatter of the next, the first and the last beyond it).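

In this assay, cyclohexyl in place of butyl on a triple-bonded carbon gives a 1.5-fold higher number from compound 3 to compound 4 (0.18 log units; within the scatter), on the core shared by these two compounds. Among these compounds, this is the first comparison at this place of an open chain with a ring, where compound 1 and compound 2 set only one ring against another, and here too the group leaves the number within the scatter. Nothing on hand accounts for how closely the two groups read.

Going by these compounds, whether a longer chain, or a chain carrying an amine or a carboxylic acid, on the triple-bonded carbon would give a step beyond the scatter remains open. Also open, on these data alone, is whether a step at this place on the core of compound 3 would carry over to the core of compound 1.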